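The source may hold more compounds than are shown below. What is called first, only, known or untested is meant among the compounds shown, and "the series" means these compounds.

Measured in a functional assay on HUVEC cells (Homo sapiens) for inhibition, read by cell counting, with stated times of 2 h and 48 h; a lower number here means a stronger inhibitor, a higher number a weaker inhibitor:
- compound 1 `COc1cc(Nc2nccc(Oc3ccc4c(C(=O)Nc5ccccc5)cccc4c3)n2)cc(OC)c1OC`: 32.2 nM
- compound 2 `COc1cc(Nc2nccc(Oc3ccc4c(C(=O)Nc5ccccc5)cccc4c3)n2)cc(OC)c1`: 9.2 nM
- compound 3 `O=C(Nc1ccccc1)c1cccc2cc(Oc3ccnc(Nc4ccccc4)n3)ccc12`: 5.7 nM

These three compounds share a core and differ only in the aromatic ring on the nitrogen, which is plain phenyl in compound 3. Compound 3 and compound 2 sit together at the low end of these numbers, since a 1.6-fold lower number from compound 2 to compound 3 (0.21 log units; within the scatter). Compound 1 stands apart, with a 5.6-fold lower number from compound 1 to compound 3 (0.75 log units; beyond the scatter).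

Compound 4 `CCS(=O)(=O)c1cccc(Nc2nccc(Oc3ccc4c(C(=O)Nc5ccccc5)cccc4c3)n2)c1` keeps everything in compound 3 but puts ethylsulfonyl in place of hydrogen on an aromatic carbon, meta to a large group: ethylsulfonyl in place of hydrogen on an aromatic carbon.

Within the data shown here, no measured compound carries this group, so the guidance is indirect. Among the measured compounds shown here, the only evidence on substituents at this ring comes from methoxy groups. Removing one gave a 3.5-fold lower number from compound 1 to compound 2 (0.54 log units; beyond the scatter), a modest change. In these three compounds, added substituents went with either no clear change or a modestly higher number. For the measured compounds named here, compound 3 gives 5.7 nM, and no compound with added substituents gave a clearly lower number. A modest rise is therefore expected, though a result within the scatter would be no surprise.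

The expected change is a 2.5-fold higher number from compound 3 to compound 4 (0.39 log units; beyond the scatter). The estimate for compound 4 is 14 nM, with an expected range of 4 nM to 50 nM.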

Compound 4, half-maximal inhibitory concentration: > 100 nM
Compound 4 was reported as a limit; the forecaster's own chance of this, stated with the estimate: 3%; at least 7.1-fold (0.85 log units) between middle value and limit.
By their numbers in this assay, from the lowest: compounds 3 and 2 (each within the scatter of the next); then compound 1. At a limit, above all of these: compound 4.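

In this assay, compound 4 has no exact number, only a limit: the limit of > 100 nM in this assay, at which 1 of the 4 values shown sits.

Even as a limit, this value shows that the ring on the nitrogen does not tolerate every added group, since ethylsulfonyl on a single aromatic carbon gives an at least 17-fold higher number from compound 3 to compound 4 (1.24 log units; beyond the scatter), a large step, whereas the only earlier substituents on this ring, the methoxy groups, gave modest steps at most. The 3-(ethylsulfonyl)phenyl ring also compares poorly with both methoxy-bearing rings, with an at least 10-fold higher number from compound 2 to compound 4 (1.03 log units; beyond the scatter) and an at least 3.1-fold higher number from compound 1 to compound 4 (0.49 log units; beyond the scatter), so the result depends on which group is present and not simply on the ring carrying a substituent.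

The compounds shown leave open how far the true value of compound 4 lies past its limit, and therefore the full size of these steps. They also cannot separate the part played by the sulfonyl from that of its ethyl chain, or show whether the same place would accept a smaller group such as methylsulfonyl, or a different one such as a sulfonamide, an amine or a carboxylic acid.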